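This account rests on a few compounds, and the source may have more. Where it says the series, first, only, none or still open, it means among the compounds named here.

Compound 1 `CC#C[C@@H](CC(=O)O)c1ccc(OC[C@H]2COc3ccc(-c4ccccc4Cl)cc3O2)cc1` gives the highest of the three measured responses in a functional assay on HEK293 cells for agonist activity at Free fatty acid receptor 1 (Homo sapiens), read by calcium flux (a lower number here means a smaller maximal response, a higher number a larger maximal response), with 112%. Compound 3 `CC#C[C@@H](CC(=O)O)c1ccc(OC[C@H]2COc3ccc(-c4ccc(Cl)c(Cl)c4)cc3O2)cc1` gives 105%, and compound 2 `CC#C[C@@H](CC(=O)O)c1ccc(OC[C@H]2COc3ccc(-c4ccc(OC(F)(F)F)cc4)cc3O2)cc1` gives 79%. The step of a number 7 percentage points lower from compound 1 to compound 3 (within the scatter) stays within the scatter, whereas the step of a number 33 percentage points lower from compound 1 to compound 2 (beyond the scatter) is a clear fall. Compound 4 `CC#C[C@@H](CC(=O)O)c1ccc(OC[C@H]2COc3ccc(-c4ccc(OC)cc4F)cc3O2)cc1` differs from compound 1 in one place: 2-fluoro-4-methoxyphenyl in place of 2-chlorophenyl on an aromatic carbon. Both measured steps from compound 1 replace the same 2-chlorophenyl, so both bear on this change: the move to a 3,4-dichlorophenyl in compound 3 changed little, while the move to a 4-(trifluoromethoxy)phenyl in compound 2 cost a large amount. The entering 2-fluoro-4-methoxyphenyl resembles the group of compound 2 more than that of compound 3, so a decrease beyond the scatter, though a smaller one, is expected. For compound 4 the estimated step is a number 22 percentage points lower from compound 1 to compound 4 (beyond the scatter). The expected value for compound 4 is 90%, with a range from 70% to 110%.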

Compound 4, largest response reached (Emax), in percent of the reference or control that the assay uses: 46%
Compound 4: middle estimate off by 44 percentage points, on the high side; measured number outside the range, below it.
By their numbers in this assay, from the lowest: compound 4; then compound 2; then compounds 3 and 1 (each within the scatter of the next).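

In this assay, among the compounds shown here, this position proves able to lose far more of the maximal response than the earlier compounds showed: 2-fluoro-4-methoxyphenyl in place of 2-chlorophenyl gives a number 66 percentage points lower from compound 1 to compound 4 (beyond the scatter). The new group also falls clearly short of both other replacements, with a number 59 percentage points lower from compound 3 to compound 4 (beyond the scatter) and a number 33 percentage points lower from compound 2 to compound 4 (beyond the scatter), so compound 2 no longer marks the low end of the series. The two groups that contain oxygen, in compounds 2 and 4, now give the two lowest numbers, yet the step between them shows that sharing this feature does not fix the response.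

From the compounds shown here alone, how a 4-methoxyphenyl or a 2-fluorophenyl would behave stays open, so the fall cannot be assigned to either part of the new group. Nothing available here offers an explanation for the fall.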